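The source may hold more compounds than are shown below. What is called first, only, known or untested is meant among the compounds shown, and "the series" means these compounds.

Working series in a functional assay on SEM cells (Homo sapiens) for inhibition, read by MTT assay, with a stated time of 72 h; on this read-out lower numbers stand for stronger inhibition and higher numbers for weaker inhibition:
- compound 1 `C=C(Br)C(=O)Nc1cccc(/C=C/C(=O)Nc2ccccc2)c1`: 1100 nM
- compound 2 `C=C(Br)C(=O)Nc1cccc(/C=C/C(=O)Nc2ccc(F)cc2)c1`: 8400 nM
- compound 3 `C=C(Br)C(=O)Nc1cccc(/C=C/C(=O)Nc2cccc(F)c2)c1`: not yet measured

Compound 2 has the higher of the two numbers in this assay, which makes it the weaker of the pair. The change under consideration is 3-fluorophenyl in place of 4-fluorophenyl on an amide-type nitrogen.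

For the measured compounds named here, only one measured step bears on this, and only indirectly. It is a 7.6-fold higher number from compound 1 to compound 2 (0.88 log units; beyond the scatter), a modest step beyond the scatter, with fluoro in place of hydrogen on an aromatic carbon. Going by the values given here, no measured pair shows the fluoro changing place, so the data do not fix the size of the coming step, or even its direction. Compound 3 keeps a fluoro, so the working expectation is a partial return toward compound 1 at 1100 nM, not a full one.

The expected move is a 2.8-fold lower number from compound 2 to compound 3 (0.45 log units; beyond the scatter), smaller than the measured step and toward a lower number. Compound 3 is estimated at 3000 nM, with an expected range of 1000 nM to 9000 nM.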

Compound 3, half-maximal inhibitory concentration: 620 nM
For compound 3 the middle estimate is 4.8-fold (0.68 log units) above the measured one; measured number below the stated range.
By their numbers in this assay, from the lowest: compounds 3 and 1 (each within the scatter of the next); then compound 2.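

In this assay the place of the fluoro on the phenyl group matters, not only its presence: 3-fluorophenyl in place of 4-fluorophenyl on the amide-type nitrogen gives a 14-fold lower number from compound 2 to compound 3 (1.13 log units; beyond the scatter) and is a large step between two compounds with the same atoms. Set against the unsubstituted phenyl, the reading is a 1.8-fold lower number from compound 1 to compound 3 (0.25 log units; within the scatter) and so gives no separation between the two compounds, which means that the fluoro is tolerated as 3-fluorophenyl and that the weaker number of compound 2 goes with 4-fluorophenyl, not with fluoro as such. Nothing available explains why the two fluorophenyl groups differ so widely in this cell read-out.

The compounds shown leave open whether this dependence on place belongs to fluoro alone or also holds for larger groups, as 3-chlorophenyl, 3-methoxyphenyl or 3-(trifluoromethyl)phenyl on the amide-type nitrogen would show. Also open, as far as these compounds go, is whether 3-fluorophenyl keeps its standing once the shared core is changed, since all three compounds carry that core unaltered and are compared in this assay only.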